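Methyl Added at the Imidazole Ring in Two Settings

This account rests on a few compounds, and the source may have more. Where it says the series, first, only, none or still open, it means among the compounds named here.

The series rests on three measured compounds and one awaiting measurement. Compound 1 `COc1ccc(Br)cc1CCc1c(Cl)cccc1-c1nccn1C` and compound 2 `CCn1ccnc1-c1cccc(Cl)c1CCc1cc(Br)ccc1OC` share one core; compound 3 `CCc1cn(C)c(-c2ccccc2CCc2cc(Br)ccc2OC)n1` and compound 4 `COc1ccc(Br)cc1CCc1ccccc1-c1nc(C(C)C)cn1C` share another. The difference between the two cores is not broken down here.

In an assay on isolated protein for binding affinity to Melanocortin receptor 4 (Homo sapiens) (on this read-out lower numbers stand for stronger inhibition and higher numbers for weaker inhibition), compound 1 gives 300 nM. In this assay compound 2 gives 310 nM. The change from compound 1 to compound 2 is methyl in place of hydrogen on a saturated chain carbon bound to an aromatic nitrogen, and it made a 1.0-fold higher number from compound 1 to compound 2 (0.01 log units; within the scatter). Compound 3 stands apart: in this assay compound 3 gives 690 nM, a number beyond the scatter from both compound 1 and compound 2.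

Compound 4 carries the same kind of change relative to compound 3, namely (methyl in place of hydrogen on a saturated chain carbon bound to an aromatic carbon and a saturated chain carbon). The two places are not identical: in the earlier pair the methyl entered on a saturated chain carbon bound to an aromatic nitrogen, while here it enters on a saturated chain carbon bound to an aromatic carbon and a saturated chain carbon, so the change is of the same kind rather than the same.

Because a 1.0-fold higher number from compound 1 to compound 2 (0.01 log units; within the scatter) lay within the scatter, compound 4 is expected to move only a little, giving an estimated 1.0-fold higher number from compound 3 to compound 4 (0.01 log units; within the scatter). The estimate for compound 4 in this assay is therefore 700 nM, expected to fall between 300 nM and 1600 nM.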

Compound 4, inhibition constant: 1600 nM
Beside the measured number, compound 4's estimate is 2.3-fold (0.36 log units) below it; measured number inside the range.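

In this assay the added methyl gave a 2.3-fold higher number from compound 3 to compound 4 (0.37 log units; beyond the scatter) on one core and a 1.0-fold higher number from compound 1 to compound 2 (0.01 log units; within the scatter) on the other, and only the former lies beyond the scatter, yet the two steps cannot be told apart: the same change on two cores in this assay, a 1.0-fold higher number (0.01 log units; within the scatter) from compound 1 to compound 2 and a 2.3-fold higher number (0.37 log units; beyond the scatter) from compound 3 to compound 4, 2.2-fold (0.35 log units) apart, within the scatter of two such steps

This gives no firm sign that the change behaves differently on the two cores. Among the compounds shown here, it does not show that the change carries over unaltered: only two pairs stand behind the comparison, and the methyl enters at different places, on a saturated chain carbon bound to an aromatic nitrogen in one pair and on a saturated chain carbon bound to an aromatic carbon and a saturated chain carbon in the other.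

The compounds shown leave open whether the gap between the two steps would persist if the methyl entered at the same place on both cores. They also leave open how the number would move if the isopropyl of compound 4 gave way to a longer chain such as n-butyl, or to a group of another kind such as an amine or a carboxylic acid.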